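The compounds below may be only part of what the source reports. "The series", "measured", "known", "first", "only" and "open" are said of these compounds alone.

Measured compounds in a functional assay on RS4-11 cells (Homo sapiens) for inhibition, read by CCK-8 assay, with a stated time of 48 h, tested at 20 uM; a higher number here means more inhibition of growth at the concentration tested, a lower number less inhibition of growth:
compound 1 `N#C/C(=C\c1ccccc1OS(=O)(=O)c1ccccc1[N+](=O)[O-])C(=O)Nc1nnc(Cc2cccc3ccccc23)s1` — 66%
compound 2 `N#C/C(=C\c1ccccc1OS(=O)(=O)c1ccc(Cl)cc1)C(=O)Nc1nnc(Cc2cccc3ccccc23)s1` — 68%
compound 3 `N#C/C(=C\c1ccccc1OS(=O)(=O)c1ccc(F)cc1)C(=O)Nc1nnc(Cc2cccc3ccccc23)s1` — 68%

Compound 2 stands level with compound 3 at the digits printed, the two together the highest of the three numbers in this assay, and its nearest neighbour is compound 3: no change at the digits printed from compound 2 to compound 3 (within the scatter). Its furthest is compound 1: a number 2 percentage points higher from compound 1 to compound 2 (within the scatter), and the parallel step a number 2 percentage points higher from compound 1 to compound 3 (within the scatter) is of the same size. All three measured steps stay within the scatter, so the three compounds read as one level.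

Compound 4 `Cc1ccc(Cc2nnc(NC(=O)/C(C#N)=C/c3ccccc3OS(=O)(=O)c3ccc(Cl)cc3)s2)cc1` is not yet measured in this assay. From compound 2 it differs in one place: 4-methylphenyl in place of naphthalen-1-yl on a saturated chain carbon bound to an aromatic carbon

Within the data shown here, none of the measured steps bears on this place. Among the measured compounds shown here, every step so far changes the group on the sulfonyl sulfur or a substituent on it, while the (naphthalen-1-yl)methyl is common to compounds 1, 2 and 3 and is never varied. The series therefore gives no measure of how a change at this position moves the number, and no direction can be taken from it; the only anchor is the common level of the three compounds. On that basis compound 4 is expected near the level of compound 2, estimated at 58% with a range of 28% to 80%, the range wide for lack of any comparable step. The expected step from compound 2 is a number 10 percentage points lower from compound 2 to compound 4 (within the scatter).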

Compound 4, percent growth inhibition at one concentration: 72%
Compound 4: middle estimate off by 14 percentage points, on the low side; the measured number falls inside the stated range.
By their numbers in this assay, from the lowest: compounds 1, 2, 3 and 4 (each within the scatter of the next).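

In this assay, the step at this place reads a number 4 percentage points higher from compound 2 to compound 4 (within the scatter), which gives the saturated chain carbon bound to an aromatic carbon a measured step that compounds 1, 2 and 3 could not supply. Replacing naphthalen-1-yl with 4-methylphenyl, with one six-membered aromatic ring in place of two, leaves compound 4 level with compound 2, so in this pair the second aromatic ring of naphthalen-1-yl is not required to hold the level at the single concentration tested. No available evidence accounts for the two numbers staying level across this change.

This single step, read with 4-chlorophenyl on the sulfonyl sulfur, leaves open whether the same change holds with 2-nitrophenyl or 4-fluorophenyl there, and how an unsubstituted phenyl, a pyridine ring, a cyclohexyl or a longer chain would read in place of 4-methylphenyl. The single concentration also leaves open whether compound 2 and compound 4 would stay level across a range of concentrations.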